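Chloro in place of fluoro in compound 2

The compounds below may be only part of what the source reports. "The series", "measured", "known", "first", "only" and "open" are said of these compounds alone.

Compound 1 (`N#C/C(=C\c1ccccc1OS(=O)(=O)c1ccc([N+](=O)[O-])cc1)C(=O)Nc1nnc(Cc2ccc(F)cc2)s1`) gives 18% in a functional assay on HL-60 cells (Homo sapiens) for inhibition, read by CCK-8 assay, with a stated time of 48 h, tested at 20 uM; a lower number here means less inhibition of growth, a higher number more inhibition of growth at the concentration tested
Compound 2 (`N#C/C(=C\c1ccccc1OS(=O)(=O)c1ccc(F)cc1)C(=O)Nc1nnc(Cc2ccc(F)cc2)s1`) gives 13% in this assay

In this assay compound 2 stands at 13% and compound 1 at 18% and these two values lie within the scatter of each other. Compound 3 (`N#C/C(=C\c1ccccc1OS(=O)(=O)c1ccc(F)cc1)C(=O)Nc1nnc(Cc2ccc(Cl)cc2)s1`) follows from compound 2 by one change (chloro in place of fluoro on an aromatic carbon), chloro in place of fluoro on an aromatic carbon, which turns 4-fluorobenzyl into 4-chlorobenzyl. Among the compounds with values here, only one measured step is available (a number 5 percentage points lower from compound 1 to compound 2 (within the scatter)), and it has fluoro in place of nitro at a different place in the molecule. Within the data shown here, it therefore bears on the new change only indirectly, and no measured pair tests the 4-fluorobenzyl group itself. With so little to go on, no shift beyond the scatter is expected. The estimated step (a number 4 percentage points higher from compound 2 to compound 3 (within the scatter)) is small. Compound 3 is expected at 17% in this assay with an estimated range from 6% to 35% in this measurement.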

Compound 3, percent growth inhibition at one concentration: 20%
Estimate against measurement, compound 3: 3 percentage points below, within the range that was stated.
By their numbers in this assay, from the lowest: compounds 2, 1 and 3 (each within the scatter of the next).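

Within the data shown here, this is the first measured change on the benzyl end of the molecule. In this assay, 4-chlorobenzyl in place of 4-fluorobenzyl gives a number 7 percentage points higher from compound 2 to compound 3 (within the scatter) and so does not move growth inhibition beyond the scatter at this place, para to a large group. No data shown here explain this result or give any property of the two halogens at this position.

On these data alone, whether a group of another kind on this aromatic carbon, such as an amine, a carboxylic acid or a longer alkyl chain, would shift the value beyond the scatter remains open. Also open, as far as these compounds go, is what the nitro group of compound 1 and the chloro group of compound 3 would give together in one molecule.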